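Chloro to trifluoromethoxy: the next step in the series

The source may report more compounds than this note shows. Statements on the series, on what has been measured and on what is new or still open speak of the compounds shown alone.

Values in a functional assay on PC-3 cells (Homo sapiens) for inhibition, read by sulforhodamine B assay, with a stated time of 48 h; on this read-out higher numbers stand for weaker inhibition of growth and lower numbers for stronger inhibition of growth:
- compound 1 `Ic1ccc(Cn2cc(CCCOc3cccc4cccnc34)nn2)cc1`: 24.7 ug/mL
- compound 2 `Clc1ccc(Cn2cc(CCCOc3cccc4cccnc34)nn2)cc1`: 3.6 ug/mL
- compound 3 `FC(F)(F)Oc1ccc(Cn2cc(CCCOc3cccc4cccnc34)nn2)cc1`: not yet measured

Compound 2 stands lowest of the two numbers, at 3.6 ug/mL. The next change is trifluoromethoxy in place of chloro on an aromatic carbon, para to a large group. Going by the values given here, the only measured step touching this group is a 6.9-fold lower number from compound 1 to compound 2 (0.84 log units; beyond the scatter), chloro in place of iodo. It shows that exchanging this group can move the number in this assay by a modest amount. Among the compounds with values here, no measured compound carries trifluoromethoxy, so the direction remains uncertain. With compound 2 already the lower of the two, a modest move toward a higher number is expected, and the estimated step is a 2.2-fold higher number from compound 2 to compound 3 (0.35 log units; beyond the scatter). Compound 3 is estimated at 8 ug/mL, with an expected range from 2.5 ug/mL to 25 ug/mL.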

Compound 3, concentration for 50% growth inhibition: 5 ug/mL
For compound 3 the middle estimate is 1.6-fold (0.20 log units) above the measured one, and the stated range covers the measured number.
By their numbers in this assay, from the lowest: compounds 2 and 3 (each within the scatter of the next); then compound 1.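

In this assay trifluoromethoxy in place of chloro on an aromatic carbon, para to a large group, gives a 1.4-fold higher number from compound 2 to compound 3 (0.14 log units; within the scatter) and so leaves compounds 2 and 3 indistinguishable, even though the entering group has 5 heavy atoms against 1 for chloro. Trifluoromethoxy in place of iodo gives a 4.9-fold lower number from compound 1 to compound 3 (0.69 log units; beyond the scatter) and so sets iodo apart from both other groups at this position, not from chloro alone. No evidence is available to explain these results.

As far as these compounds go, what an amine or a carboxylic acid would do at this position remains open, as does where fluoro or bromo would fall relative to chloro and iodo. Also open, from the compounds shown here alone, is whether these steps would hold with a longer chain in the shared core.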